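The source may hold more compounds than are shown below. What is called first, only, known or untested is meant among the compounds shown, and "the series" means these compounds.

Measured compounds in a functional assay (aorta) with Rattus norvegicus as the target; a lower number here means that less compound is needed, a higher number that more compound is needed for the effect:
- compound 1, `COc1cccc(NC(=O)NC2CC(C)(C)Oc3ccc(Cl)cc32)c1`: > 10000 nM
- compound 2, `Cc1ccccc1NC(=O)NC1CC(C)(C)Oc2ccc(Cl)cc21`: > 10000 nM
- compound 3, `CC1(C)CC(NC(=O)Nc2ccccc2Cl)c2cc(F)ccc2O1`: > 30000 nM

None of these three values is a number; each is a limit of the assay. Compound 1 sits at the limit of > 10000 nM in this assay, at which 2 of the 3 values shown sit. Compound 2 sits at the same limit. Compound 3 sits at the limit of > 30000 nM in this assay, at which 1 of the 3 values shown sits. For the measured compounds named here, the only step between measured compounds, a step that the two limits leave unreadable from compound 1 to compound 2, is therefore unreadable in size, and no measured step bears on the change now in question.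

Compound 4, `CC1(C)CC(NC(=O)Nc2ccccc2Cl)c2cc(Cl)ccc2O1`, differs from compound 3 by chloro in place of fluoro on an aromatic carbon. Going by the values given here, compound 1 and compound 2 each carry a chloro group on the shared core and each gives only a limit, so the measured data contain no example of a chloro-bearing core reaching a numerical value in this assay. Among the compounds with values here, with every value so far a limit, no direction can be read, and an effect beyond the scatter cannot be predicted from the series.

The step from compound 3 to compound 4 is expected to be a number no higher from compound 3 to compound 4 (the limit leaves the size open), that is, essentially none. Compound 4 is therefore expected at 30000 nM, with a range of 10000 nM to 100000 nM, and most likely to be reported again only as a limit rather than a number.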

Compound 4, half-maximal effective concentration: > 300000 nM
Compound 4 gave a limit, no number; the forecaster's own chance of this, stated with the estimate: 80%; middle value at least 10-fold (1.00 log units) from the limit.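

In this assay compound 4 gives > 300000 nM, a limit and not a number. The steps from compound 1, compound 2 and compound 3 to compound 4 cannot be read in size, as all four values are limits. The compounds shown leave open whether any change on the shared core reaches a numerical value in this assay.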